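Arylamino in place of piperidinyl: expectation for compound 4

This account rests on a few compounds, and the source may have more. Where it says the series, first, only, none or still open, it means among the compounds named here.

Compound 1 `FC(F)(F)c1ccc(CSc2nc(N3CCCCC3)c3ccccc3n2)cc1` gives 18600 nM in a functional assay on MGC-803 cells (Homo sapiens) for cytotoxicity, read by MTT assay, with a stated time of 72 h (a higher number here means a weaker inhibitor, a lower number a stronger inhibitor), and holds the lowest of the two numbers in this small set, the nearest being compound 3. Compound 3 `Cc1ccccc1Nc1nc(SCc2ccc(C(F)(F)F)cc2)nc2ccccc12` gives 24400 nM in this assay, and the step of a 1.3-fold higher number from compound 1 to compound 3 (0.12 log units; within the scatter) stays within the scatter. Compound 2 `CCOc1ccccc1Nc1nc(SCc2ccc(C(F)(F)F)cc2)nc2ccccc12` reaches only a limit in this assay, > 50000 nM. Accordingly the step of an at least 2.6-fold higher number from compound 1 to compound 2 (0.42 log units; beyond the scatter) and the step of an at least 2.0-fold lower number from compound 2 to compound 3 (0.31 log units; beyond the scatter) are both at least modest, their true size capped by the limit of > 50000 nM in this assay, at which 1 of the 3 values shown sits.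

Compound 4 `Fc1ccc(Nc2nc(SCc3ccc(C(F)(F)F)cc3)nc3ccccc23)cc1Cl` awaits measurement in this assay. It differs from compound 1 by (3-chloro-4-fluorophenyl)amino in place of piperidin-1-yl on an aromatic carbon. The two measured steps from compound 1 are the relevant ones, as each also swaps piperidin-1-yl for an arylamino group at the same aromatic carbon: one lies within the scatter, the other is at least modest towards a higher number. Within the data shown here, for compound 4 a number close to or somewhat above that of compound 1 is therefore expected, with no step clearly beyond the scatter. Compound 4 is estimated at 26000 nM, within 11000 nM to 60000 nM. The expected step is a 1.4-fold higher number from compound 1 to compound 4 (0.15 log units; within the scatter).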

Compound 4, half-maximal inhibitory concentration: > 50000 nM
Compound 4 gave a limit, no number; the forecaster's own chance of this, stated with the estimate: 25%; middle value at least 1.9-fold (0.28 log units) away from the limit.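

In this assay compound 4 reaches only a limit, > 50000 nM. With an at least 2.6-fold higher number from compound 1 to compound 4 (0.42 log units; beyond the scatter) and an at least 2.0-fold higher number from compound 3 to compound 4 (0.31 log units; beyond the scatter), the rise seen with compound 2 proves not to be tied to an ethoxy group: 3-chloro-4-fluorophenyl on the same nitrogen also ends at the limit, and 2-methylphenyl in compound 3 is the only one of the three arylamino groups shown that stays within the scatter of piperidin-1-yl. The step between compound 2 and compound 4 cannot be read, and the true size of the two readable steps remains capped: the limit of > 50000 nM in this assay, at which 2 of the 4 values shown sit.

Compound 3 and compound 4 carry different substituents on the ring, which leaves the separate contributions of the chlorine and the fluorine unresolved, and 3-chlorophenyl or 4-fluorophenyl on the same nitrogen would separate them. Also open, as far as these compounds go, is how morpholin-4-yl or benzylamino on this aromatic carbon would compare with piperidin-1-yl in compound 1.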